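The source may report more compounds than this note shows. Statements on the series, on what has been measured and on what is new or still open speak of the compounds shown alone.

In a functional assay on PC-3 cells (Homo sapiens) for antiproliferative activity, read by MTT assay, with a stated time of 48 h (a lower number here means a stronger inhibitor, a higher number a weaker inhibitor), compound 1 `COc1cc(-c2nnc(SCC(=O)c3ccc(C(F)(F)F)cc3)n2N)cc(OC)c1OC` reaches only the assay limit of > 100000 nM. Compound 2 `COc1cc(-c2nnc(SCC(=O)c3cccc(Br)c3)n2N)cc(OC)c1OC` likewise stops at the limit of > 100000 nM. For the measured compounds named here, compound 3 `COc1ccc(C(=O)CSc2nnc(-c3cc(OC)c(OC)c(OC)c3)n2N)cc1` is the one member of the set with an actual number, giving 97900 nM, yet the steps of an at least 1.0-fold lower number from compound 1 to compound 3 (0.00 log units; that floor lies within the scatter) and an at least 1.0-fold lower number from compound 2 to compound 3 (0.00 log units; that floor lies within the scatter) both remain within the scatter, so compound 3 does not stand apart from its two companions. Compound 4 `COc1cc(-c2nnc(SCC(=O)Nc3ccc(C)cc3)n2N)cc(OC)c1OC` differs from compound 3 by (4-methylphenyl)amino in place of 4-methoxyphenyl on a carbonyl carbon. Going by the values given here, no measured step exchanges a ketone for an amide of this kind, so nothing among the three measured compounds speaks for a move in either direction beyond the scatter. Compound 4 is therefore expected at about 100000 nM (between 40000 nM and 250000 nM), an estimated step of a 1.0-fold higher number from compound 3 to compound 4 (0.01 log units; within the scatter) that may again end as a limit.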

Compound 4, half-maximal inhibitory concentration: 43100 nM
Beside the measured number, compound 4's estimate is 2.3-fold (0.37 log units) above it, and the stated range covers the measured number.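

For the compounds shown here, putting (4-methylphenyl)amino on this carbonyl carbon, which turns the ketone into an amide, gives the first step in the set that is beyond the scatter: in this assay there is a 2.3-fold lower number from compound 3 to compound 4 (0.36 log units; beyond the scatter). The same exchange also reads as an at least 2.3-fold lower number from compound 2 to compound 4 (0.36 log units; beyond the scatter) and as an at least 2.3-fold lower number from compound 1 to compound 4 (0.36 log units; beyond the scatter), but these two are only floors, because each starts from a limit: the limit of > 100000 nM in this assay, at which 2 of the 4 values shown sit.

With a single amide shown, it remains open whether the drop comes from the amide itself or from its methyl group. A (4-methoxyphenyl)amino or plain phenylamino group on the same carbonyl carbon would help separate the two.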